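Thiazolidine propiolamides: tert-butyl replacing phenyl at the ring carbon

This account rests on a few compounds, and the source may have more. Where it says the series, first, only, none or still open, it means among the compounds named here.

Of the compounds shown here, two have numbers so far. Compound 1 `C#CC(=O)N1C(C(CC)CCCC)SC[C@@H]1C(=O)OCC` gives 1700 nM in a functional assay on Huh-7 cells (Homo sapiens) for inhibition, read by sulforhodamine B assay; on this read-out lower numbers stand for stronger inhibition and higher numbers for weaker inhibition. Within the data shown here, compound 2 `C#CC(=O)N1C(c2ccccc2)SC[C@@H]1C(=O)OCC` gives 5300 nM in the same read-out, which is the higher of the two numbers; the only measured step, a 3.1-fold higher number from compound 1 to compound 2 (0.49 log units; beyond the scatter), lies beyond the scatter. Compound 3 `C#CC(=O)N1C(C(C)(C)C)SC[C@@H]1C(=O)OCC` has not yet been measured. It differs from compound 2 in one place: tert-butyl in place of phenyl on a saturated ring carbon.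

Among the measured compounds shown here, the one step that bears on this change is the exchange of a branched alkyl for phenyl, a 3.1-fold higher number from compound 1 to compound 2 (0.49 log units; beyond the scatter); tert-butyl is again a branched alkyl, with no ring, though a shorter one than 1-ethylpentyl. Compound 3 is therefore expected to move back toward compound 1, in the direction of a lower number, but with no ground to assume it reaches that far. The step expected from compound 2 to compound 3 is a 2.1-fold lower number from compound 2 to compound 3 (0.33 log units; beyond the scatter). For compound 3 the estimate in this assay is 2500 nM, within a range of 1000 nM to 6500 nM.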

Compound 3, half-maximal inhibitory concentration: 800 nM
For compound 3 the middle estimate is 3.1-fold (0.49 log units) above the measured one; the measured number lies below the stated range.
By their numbers in this assay, from the lowest: compound 3; then compound 1; then compound 2.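

In this assay, the saturated ring carbon proves more sensitive to the choice of alkyl group than the first pair could show: a 6.6-fold lower number from compound 2 to compound 3 (0.82 log units; beyond the scatter), and the change does more than recover the ground lost between 1-ethylpentyl and phenyl, a 3.1-fold higher number from compound 1 to compound 2 (0.49 log units; beyond the scatter). Tert-butyl also passes 1-ethylpentyl, with a 2.1-fold lower number from compound 1 to compound 3 (0.33 log units; beyond the scatter), so the two groups without a ring are themselves separated beyond the scatter and the shorter branched group carries the lowest number of the three. Nothing available on these compounds accounts for this order.

The three groups leave open whether the lower number follows the shorter chain, the branching on the carbon attached to the ring, or the absence of an aromatic ring; isopropyl, a straight butyl chain and cyclohexyl at the same ring carbon would separate these readings. Also open is whether the order among these groups holds when the ethoxycarbonyl group gives way to a carboxylic acid or an amide.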